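Adding a tert-Butyl Group to the Phenyl of Compound 2

The source may report more compounds than this note shows. Statements on the series, on what has been measured and on what is new or still open speak of the compounds shown alone.

Three compounds have been measured in a functional assay on HT-29 cells (Homo sapiens) for antiproliferative activity, read by MTT assay, with a stated time of 96 h; a higher number here means a weaker inhibitor, a lower number a stronger inhibitor:

Compound 1 `CCN(CC)c1ccc(N2C(=O)NC3(CSC4=C3C(=O)c3ncccc3C4=O)C2=O)cc1` gives 50 nM.
Compound 2 `O=C1C2=C(C(=O)c3ncccc31)C1(CS2)NC(=O)N(c2ccccc2)C1=O` gives 2 nM.
Compound 3 `O=C1NN(c2ccccc2)C(=O)C2(CSC3=C2C(=O)c2ncccc2C3=O)N1` gives 550 nM.

Compound 2 stands lowest of the three numbers; compound 1 and compound 3 both give higher numbers, and both differences lie beyond the scatter. Compound 1 differs from compound 2 only by a diethylamino group on the phenyl ring, and the measured step is a 25-fold lower number from compound 1 to compound 2 (1.40 log units; beyond the scatter). The new compound 4 `CC(C)(C)c1ccc(N2C(=O)NC3(CSC4=C3C(=O)c3ncccc3C4=O)C2=O)cc1` differs from compound 2 in a single place: tert-butyl in place of hydrogen on an aromatic carbon. Going by the values given here, the one step that bears on this change is the diethylamino-to-hydrogen step, which shows that a group at this aromatic carbon went along with a much higher number. Tert-butyl is not diethylamino, so the size of the effect is uncertain, but the direction points to a higher number for compound 4. The step expected in this assay is a 7.5-fold higher number from compound 2 to compound 4 (0.88 log units; beyond the scatter). Compound 4 is estimated to give 15 nM, with a range from 4 nM to 60 nM.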

Compound 4, half-maximal inhibitory concentration: 150 nM
Beside the measured number, compound 4's estimate is 10-fold (1.00 log units) below it; measured number above the stated range.
By their numbers in this assay, from the lowest: compound 2; then compound 1; then compound 4; then compound 3.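

In this assay there is a 75-fold higher number from compound 2 to compound 4 (1.88 log units; beyond the scatter) when tert-butyl enters, so a second group at this aromatic carbon also goes with a much higher number than the unsubstituted phenyl of compound 2. The rise is therefore not tied to diethylamino alone, since tert-butyl, made of carbon only and with no ring, moves the number the same way. The two groups are still not equal: there is a 3.0-fold higher number from compound 1 to compound 4 (0.48 log units; beyond the scatter) on replacing diethylamino with tert-butyl, so which group sits here matters as well as whether one does.

The data shown offer no measurement that explains these steps.

From the compounds shown here alone, whether a methyl group, a fluorine atom or a hydroxyl group at this carbon would keep the number close to that of compound 2 stays open, and so does whether tert-butyl would have a similar effect on the core of compound 3.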